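Allyl to butyl on the amine: expected size of step

This account rests on a few compounds, and the source may have more. Where it says the series, first, only, none or still open, it means among the compounds named here.

Of the compounds shown here, three carry numbers so far. Compound 1 `C=CCNC(=C\C(=O)/C=C/c1ccc(O)c(OC)c1)/C=C/c1ccc(O)c(OC)c1` is measured in a functional assay for inhibition, read by spectrophotometry, with a stated time of 30 min, tested at 1 uM (on this read-out higher numbers stand for more inhibition at the one concentration tested (going by the name of the read-out) and lower numbers for less inhibition), and gives 0.1%. Compound 3 `CCC(C)NC(=C\C(=O)/C=C/c1ccc(O)cc1)/C=C/c1ccc(O)cc1` gives 0.03% in this assay, and compound 2 `COc1cc(/C=C/C(=O)/C=C(/C=C/c2ccc(OC(C)=O)c(OC)c2)NC2CCCCC2)ccc1OC(C)=O` gives 0.01%. The number for compound 1 lies within the usual scatter of both the number for compound 3 and the number for compound 2, so the three numbers are not told apart by this assay, and none of them shows inhibition of any size at the concentration used.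

Compound 4 `CCCCNC(=C\C(=O)/C=C/c1ccc(O)c(OC)c1)/C=C/c1ccc(O)c(OC)c1` has not been measured. Against compound 1 it differs in one place: propyl in place of vinyl on a saturated chain carbon bound to an amine nitrogen. Cut one bond further out, the same change reads allyl to butyl, allylamino to butylamino.

Among the compounds with values here, no step between two measured compounds is available to show what a change of this kind does on the shared core. The three measured compounds, which differ in the amine substituent and in the aryl substitution, all sit near zero inhibition. On that basis the step from compound 1 to compound 4 is expected to be none beyond the scatter, no change at the digits printed from compound 1 to compound 4 (within the scatter). Compound 4 is therefore estimated at 0.1% in this assay, with a range from -5% to 10%.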

Compound 4, a percentage reported as inhibition, at one concentration (the size of the read-out at that concentration, not a potency): 0.08%
Compound 4: the middle estimate sits 0 percentage points above what was measured; measured number inside the range.
By their numbers in this assay, from the lowest: compounds 2, 3, 4 and 1 (each within the scatter of the next).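

Propyl in place of vinyl on a saturated chain carbon bound to an amine nitrogen gives, in this assay, a number 0 percentage points lower from compound 1 to compound 4 (within the scatter) and this is the first step in the series that can be read with only one place changed. On the shared core, allyl to butyl thus removes the double bond outside aromatic rings with no change that this read-out can tell apart from the scatter, so neither group on the amine nitrogen is separated from the other by this measurement. As both compounds of the pair sit near zero inhibition, the step cannot show how this position behaves in a compound with clear inhibition, and no measurement given here bears on a reason for the flat result.

On these data alone, whether any group at this position can lift the read-out beyond the scatter on the core of compound 1 remains open, for example a longer chain, or a chain carrying an amine or a carboxylic acid. Also open, as far as these compounds go, is whether allyl and butyl would still read alike on a core that shows clear inhibition at the concentration tested.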